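From Methyl to Amino: One Antiproliferative Step Ahead

The source may hold more compounds than are shown below. What is called first, only, known or untested is meant among the compounds shown, and "the series" means these compounds.

Measured in a functional assay on MCF7 cells (Homo sapiens) for antiproliferative activity, read by MTT assay, with a stated time of 72 h; on this read-out lower numbers stand for stronger inhibition and higher numbers for weaker inhibition:
- compound 1 `COc1ccccc1-c1ccc2ncn(-c3cc(OC)c(OC)c(OC)c3)c2c1`: 1750 nM
- compound 2 `COc1cc(-n2cnc3ccc(-c4cccc(Cl)c4)cc32)cc(OC)c1OC`: 3120 nM
- compound 3 `COc1cc(-n2cnc3ccc(-c4cccc(C)c4)cc32)cc(OC)c1OC`: 360 nM

Among these three, compound 3 has the lowest number, 360 nM, and its steps to both others lie beyond the scatter. The next compound, compound 4 `COc1cc(-n2cnc3ccc(-c4cccc(N)c4)cc32)cc(OC)c1OC`, changes one group of compound 3, with amino in place of methyl on an aromatic carbon.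

Within the data shown here, no measured compound carries amino, so the size of this step cannot be read directly from the data. Among the measured compounds shown here, the closest guide is the step that also changes only this group, an 8.7-fold lower number from compound 2 to compound 3 (0.94 log units; beyond the scatter), with methyl in place of chloro. A second guide is a 4.9-fold lower number from compound 1 to compound 3 (0.69 log units; beyond the scatter). Both are modest. By contrast, a 1.8-fold higher number from compound 1 to compound 2 (0.25 log units; within the scatter) stays within the scatter, so the two compounds without methyl give no clear order.

In this small set, compound 3 alone reaches the low end, and neither other aryl group matches it. A modest move toward weaker inhibition in this assay therefore seems likelier than a further gain, though a gain cannot be excluded. The expected change is a 2.5-fold higher number from compound 3 to compound 4 (0.40 log units; beyond the scatter). For compound 4 the estimated value is 900 nM, with an expected range from 170 nM to 3500 nM.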

Compound 4, half-maximal inhibitory concentration: 180 nM
For compound 4 the middle estimate is 5.0-fold (0.70 log units) above the measured one; measured number inside the range.
By their numbers in this assay, from the lowest: compounds 4 and 3 (each within the scatter of the next); then compounds 1 and 2 (each within the scatter of the next).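

Among these compounds, at this place, on an aromatic carbon meta to a large group, the step from methyl to amino in this assay shows a 2.0-fold lower number from compound 3 to compound 4 (0.30 log units; within the scatter) and so does not separate the two, which means that methyl is not the only group here that reaches the low end of this set. The gaps to the other aryl groups stay clear, with a 17-fold lower number from compound 2 to compound 4 (1.24 log units; beyond the scatter) as a large step and a 9.7-fold lower number from compound 1 to compound 4 (0.99 log units; beyond the scatter) as a modest one, both beyond the scatter, so 3-aminophenyl joins 3-methylphenyl apart from the 3-chlorophenyl and 2-methoxyphenyl compounds. The change adds one hydrogen-bond donor and one hydrogen-bond acceptor by count, and the number still stays within the scatter of that of compound 3, so on these two compounds that count does not register in the read-out.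

On these data alone, it remains open whether a hydroxyl, a methoxy or a dimethylamino group at this place would stay with methyl and amino or fall away with chloro. Nothing available bears on why these groups sort as they do.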